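The source may report more compounds than this note shows. Statements on the series, on what has been measured and on what is new or still open speak of the compounds shown alone.

Of the compounds shown here, three that share one core have been tested in a functional assay on SW 1116 cells (Homo sapiens) for cytotoxicity, read by MTT assay, with a stated time of 48 h; on this read-out lower numbers stand for stronger inhibition and higher numbers for weaker inhibition. Compound 1 `O=C(CSc1nnc(-c2ccncc2)o1)N/N=C/c1ccc(O)cc1` gives 12200 nM in this assay. Compound 2 `O=C(CSc1nnc(-c2ccncc2)o1)N/N=C/c1ccccc1O` gives 7380 nM, and compound 3 `O=C(CSc1nnc(-c2ccncc2)o1)N/N=C/c1cc(Cl)ccc1O` gives 5240 nM. Compound 3 thus shows the lowest of the three numbers: the step of a 2.3-fold lower number from compound 1 to compound 3 (0.37 log units; beyond the scatter) is a modest one, whereas the step of a 1.4-fold lower number from compound 2 to compound 3 (0.15 log units; within the scatter) is small enough that compound 2 and compound 3 cannot be told apart, and the step of a 1.7-fold lower number from compound 1 to compound 2 (0.22 log units; within the scatter) likewise stays inside the scatter.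

Compound 4 `O=C(CSc1nnc(-c2ccncc2)o1)N/N=C/c1cc(Br)ccc1O` has not yet been measured. It differs from compound 3 by bromo in place of chloro on an aromatic carbon. Among the measured compounds shown here, no measured step swaps one halogen for another, so nothing bears on this change directly. The nearest comparison is the step of a 1.4-fold lower number from compound 2 to compound 3 (0.15 log units; within the scatter), in which the chloro entered the same position and produced no change beyond the scatter. On that basis the exchange of chloro for bromo is expected to leave the number about where compound 3 stands. The expected step is therefore a 1.2-fold lower number from compound 3 to compound 4 (0.07 log units; within the scatter), which does not exceed the usual scatter. For compound 4 the estimated value is 4500 nM, with a range from 2200 nM to 9500 nM in this assay.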

Compound 4, half-maximal inhibitory concentration: 8150 nM
Estimate against measurement, compound 4: 1.8-fold (0.26 log units) below; low and high end bracket the measured number.
By their numbers in this assay, from the lowest: compounds 3, 2, 4 and 1 (each within the scatter of the next, the first and the last beyond it).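

In this assay, the exchange of one halogen for the other at this place, a 1.6-fold higher number from compound 3 to compound 4 (0.19 log units; within the scatter), stays inside the scatter, so compound 3 and compound 4 cannot be told apart. Bromo in place of hydrogen, a 1.1-fold higher number from compound 2 to compound 4 (0.04 log units; within the scatter), is also inside the scatter, so on an aromatic carbon para to a hydroxy group neither halogen separates its compound from compound 2. The 5-bromo-2-hydroxyphenyl group also stays inside the scatter against the 4-hydroxyphenyl group of compound 1, a 1.5-fold lower number from compound 1 to compound 4 (0.18 log units; within the scatter), whereas the 5-chloro-2-hydroxyphenyl group lies just beyond it, a 2.3-fold lower number from compound 1 to compound 3 (0.37 log units; beyond the scatter), so the modest separation seen for compound 3 is not shared by compound 4. No independent data accompany these numbers to account for them.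

The compounds shown leave open whether a fluoro, a methoxy or an amine at this same place would give a number beyond the scatter of compound 2. They also leave open whether a halogen on the 4-hydroxyphenyl group of compound 1 would behave as it does here.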